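Replacing cycloheptyl on the aromatic nitrogen

The source may report more compounds than this note shows. Statements on the series, on what has been measured and on what is new or still open speak of the compounds shown alone.

In a functional assay on HT-29 cells (Homo sapiens) for inhibition, read by luminescence and CellTiter-Glo, with a stated time of 24 h (a lower number here means that less compound is needed, a higher number that more compound is needed for the effect), compound 1 `CCCCn1nc(C(=O)N[C@H]2COc3ccccc3N(C)C2=S)nc1Cc1ccccc1` gives 510 nM and compound 2 `CN1C(=S)[C@@H](NC(=O)c2nc(Cc3ccccc3)n(C3CCC3)n2)COc2ccccc21` gives 181 nM while compound 3 `CN1C(=S)[C@@H](NC(=O)c2nc(Cc3ccccc3)n(C3CCCCCC3)n2)COc2ccccc21` gives 5530 nM as the highest of the three numbers. The change leading to compound 4 `CN1C(=S)[C@@H](NC(=O)c2nc(Cc3ccccc3)n(C3CCN(C(=O)OC(C)(C)C)C3)n2)COc2ccccc21` is a group of 12 heavy atoms (9 carbon, 1 nitrogen, 2 oxygen; one five-membered non-aromatic ring with 1 hetero atom) in place of a group of 7 heavy atoms (7 carbon; one seven-membered non-aromatic ring of carbon only), on an aromatic nitrogen at the same aromatic nitrogen that varies across the measured compounds. The steps bearing on it are a 2.8-fold lower number from compound 1 to compound 2 (0.45 log units; beyond the scatter) and an 11-fold higher number from compound 1 to compound 3 (1.04 log units; beyond the scatter) and a 31-fold higher number from compound 2 to compound 3 (1.49 log units; beyond the scatter) so each change at this nitrogen has so far moved the number beyond the scatter. Within the data shown here, no measured compound has a hetero atom in the ring at this nitrogen, so the expectation is loose. A moderate move to a lower number is expected, namely a 3.7-fold lower number from compound 3 to compound 4 (0.57 log units; beyond the scatter) as estimated here. Compound 4 is expected at 1500 nM with an estimated range of 250 nM to 9000 nM in this assay on present evidence.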

Compound 4, half-maximal effective concentration: > 10000 nM
Compound 4 ended at the assay's limit; the forecaster's own chance of this, stated with the estimate: 8%; middle value at least 6.6-fold (0.82 log units) from the limit.
By their numbers in this assay, from the lowest: compound 2; then compound 1; then compound 3. At a limit, above all of these: compound 4.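

In this assay compound 4 gives a limit of the assay, not a number: the limit of > 10000 nM in this assay, at which 1 of the 4 values shown sits.

With a hetero atom now in the ring on this aromatic nitrogen, the step against cycloheptyl reads an at least 1.8-fold higher number from compound 3 to compound 4 (0.25 log units; that floor lies within the scatter), so no order against that group can be stated. The steps against the smaller groups are large: an at least 55-fold higher number from compound 2 to compound 4 (1.74 log units; beyond the scatter) and an at least 19-fold higher number from compound 1 to compound 4 (1.29 log units; beyond the scatter).

The compounds shown do not separate the ring hetero atom from the tert-butyl carbamate it carries. A free secondary amine in the same five-membered ring, or plain cyclopentyl, would bear on that.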